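Nitrofuran amides: chloro to trifluoromethyl on the anilide ring

This account rests on a few compounds, and the source may have more. Where it says the series, first, only, none or still open, it means among the compounds named here.

Measured so far:
compound 1 `Cc1ccc(NC(=O)c2ccc([N+](=O)[O-])o2)cc1`: 6700 nM
compound 2 `O=C(Nc1cc(Cl)ccc1Cl)c1ccc([N+](=O)[O-])o1`: 8600 nM

In a functional assay on HCC1806 cells (Homo sapiens) for cytotoxicity, read by CellTiter-Glo, with a stated time of 3 days (a lower number here means a stronger inhibitor, a higher number a weaker inhibitor), compound 1 gives 6700 nM, and compound 2 gives 8600 nM. Among the measured compounds shown here, compound 2 carries the higher of the two numbers, but its only neighbour, compound 1, sits within the scatter of it, so the two values cannot be told apart and neither compound can be called the weaker one.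

Compound 3 `O=C(Nc1cc(C(F)(F)F)ccc1Cl)c1ccc([N+](=O)[O-])o1` follows from compound 2 by one change: trifluoromethyl in place of chloro on an aromatic carbon. For the measured compounds named here, no step between two measured compounds exists, so no measured step gives the size of such a change. The expected step from compound 2 to compound 3 is small, a 1.4-fold lower number from compound 2 to compound 3 (0.16 log units; within the scatter), leaning toward a lower number but not clearly beyond the scatter. Compound 3 is therefore estimated at 6000 nM, with a range from 2000 nM to 18000 nM.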

Compound 3, half-maximal inhibitory concentration: 5100 nM
For compound 3 the middle estimate is 1.2-fold (0.07 log units) above the measured one, within the range that was stated.
By their numbers in this assay, from the lowest: compounds 3, 1 and 2 (each within the scatter of the next).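

In this assay, among the compounds shown here, the only step at this position reads a 1.7-fold lower number from compound 2 to compound 3 (0.23 log units; within the scatter) and so gives no difference that can be told from the scatter. For the compounds shown here, on this aromatic carbon, para to a chloro group, 4 heavy atoms of trifluoromethyl in place of the 1 heavy atom of chloro therefore leave the number indistinguishable from that of compound 2, which the earlier compounds, differing in more than one place, could not show. No measurement on hand bears on this result.

As far as these compounds go, whether an amine or a carboxylic acid on this same carbon would shift the number beyond the scatter stays open. Also open, from the compounds shown here alone, is what the chloro group kept in both compounds contributes, and whether any change on the shared core would matter more than this one.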